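Aryl group changes and antiproliferative values in two compounds

The compounds below may be only part of what the source reports. "The series", "measured", "known", "first", "only" and "open" are said of these compounds alone.

Measured in a functional assay on KB cells (Homo sapiens) for antiproliferative activity, read by sulforhodamine B assay, with a stated time of 3 days; a lower number here means that less compound is needed, a higher number that more compound is needed for the effect:
- compound 1 `CCC1=C(O)c2c(oc(-c3ccc(C)cc3)cc2=O)C(CC)(CC)C1=O`: 39.2 uM
- compound 2 `CCC1=C(O)c2c(oc(-c3ccc(OC)c(F)c3)cc2=O)C(CC)(CC)C1=O`: 26.7 uM

Among the measured compounds shown here, compound 2 stands level with the only other measured compound, within the scatter. For the measured compounds named here, the single measured step, a 1.5-fold lower number from compound 1 to compound 2 (0.17 log units; within the scatter), also concerns this aryl group, and it is small. Compound 3 `CCC1=C(O)c2c(oc(-c3ccc(O)c(O)c3)cc2=O)C(CC)(CC)C1=O` is the next change: 3,4-dihydroxyphenyl in place of 3-fluoro-4-methoxyphenyl on an aromatic carbon. Going by the values given here, no measured compound carries 3,4-dihydroxyphenyl, so the data indicate no clear direction in this assay. The expected change is no larger than the scatter: a 1.3-fold lower number from compound 2 to compound 3 (0.13 log units; within the scatter). For compound 3 the estimated value is 20 uM, with an expected range from 7 uM to 50 uM.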

Compound 3, concentration for half-maximal effect: 10 uM
For compound 3 the middle estimate is 2.0-fold (0.30 log units) above the measured one, and the stated range covers the measured number.
By their numbers in this assay, from the lowest: compound 3; then compounds 2 and 1 (each within the scatter of the next).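

In this assay, among the compounds shown here, 3,4-dihydroxyphenyl on the aromatic carbon next to the ring oxygen gives the first change at this place that lies beyond the scatter: a 2.7-fold lower number from compound 2 to compound 3 (0.43 log units; beyond the scatter). The step from 4-methylphenyl is also modest: a 3.9-fold lower number from compound 1 to compound 3 (0.59 log units; beyond the scatter). Nothing on hand accounts for these steps.

Whether both hydroxyl groups are needed remains open, since no compound shown carries only one. As far as these compounds go, how an aryl group bearing an amine or a carboxylic acid would compare with 3,4-dihydroxyphenyl also remains open.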